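The compounds below may be only part of what the source reports. "The series", "measured", "known", "first", "only" and "open" are said of these compounds alone.

The series shares one core, seen in compound 1 `Cc1cc(NC(=O)Cn2nnc(-c3ccccc3)n2)n(C2CCCCC2)n1`, which in an assay on HEK293 cells for activation of Kir3.1/Kir3.2 (Homo sapiens), read by thallium flux (on this read-out higher numbers stand for an effect only at larger amounts of compound and lower numbers for an effect already at smaller amounts), gives 96 nM. Compound 2 `Cc1cc(NC(=O)Cn2nnc(-c3cc(Cl)cc(Cl)c3)n2)n(C2CCCCC2)n1` gives 980 nM in this assay, and compound 3 `Cc1cc(NC(=O)Cn2nnc(-c3ccccc3F)n2)n(C2CCCCC2)n1` gives 187 nM. Compound 3 thus stands second highest of the three numbers, nearest to compound 1 and furthest from compound 2. Compound 4 `Cc1cc(NC(=O)Cn2nnc(-c3ccc(F)c(F)c3)n2)n(C2CCCCC2)n1` has not been measured; it differs from compound 3 in one place: 3,4-difluorophenyl in place of 2-fluorophenyl on an aromatic carbon. Within the data shown here, three measured steps bear on this change. a 1.9-fold higher number from compound 1 to compound 3 (0.29 log units; within the scatter), so a single fluoro on that ring left the number essentially unchanged. a 10-fold higher number from compound 1 to compound 2 (1.01 log units; beyond the scatter), and a 5.2-fold lower number from compound 2 to compound 3 (0.72 log units; beyond the scatter), which shows that a ring carrying two halogens gave a clearly higher number than either the plain or the singly fluorinated ring. Compound 4 also carries two halogens, fluorine rather than chlorine, so a modest upward step is expected, though smaller than that seen with compound 2. Compound 4 is therefore expected to give about 400 nM in this assay, within 150 nM to 1100 nM, which would mean a 2.1-fold higher number from compound 3 to compound 4 (0.33 log units; beyond the scatter).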

Compound 4, half-maximal effective concentration: 116 nM
Compound 4: the middle estimate sits 3.4-fold (0.54 log units) above what was measured; the whole stated range lies above it.
By their numbers in this assay, from the lowest: compounds 1, 4 and 3 (each within the scatter of the next); then compound 2.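

In this assay, the 3,4-difluorophenyl group shows that a ring with two halogens at this position need not give a high number: the change from the 3,5-dichlorophenyl group brings an 8.4-fold lower number from compound 2 to compound 4 (0.93 log units; beyond the scatter). Compound 4 instead stays with the plain and singly fluorinated rings, with a 1.2-fold higher number from compound 1 to compound 4 (0.08 log units; within the scatter) and a 1.6-fold lower number from compound 3 to compound 4 (0.21 log units; within the scatter), so among these four compounds only compound 2 stands apart. Nothing shown explains this difference.

Compounds 2 and 4 differ in both the halogen and its placement on the ring, so the compounds shown cannot tell which of the two goes with the higher number of compound 2. As far as these compounds go, it also remains open whether a methoxy group or an amine on this ring would keep the number near those of compounds 1, 3 and 4.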